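This account rests on a few compounds, and the source may have more. Where it says the series, first, only, none or still open, it means among the compounds named here.

Compound 1, `CCCc1nc(CC)c(C(=O)OCCCN2C(=O)c3ccccc3C2=O)n1Cc1ccc(-c2ccccc2S(=O)(=O)NC(=O)OCCC(C)C)cc1F`, in an assay on isolated protein for binding affinity to Type-2 angiotensin II receptor (Homo sapiens) (a higher number here means a weaker inhibitor, a lower number a stronger inhibitor), gives 3 nM.
Compound 2, `CCCOC(=O)NS(=O)(=O)c1ccccc1-c1ccc(Cn2c(CCC)nc(CC)c2C(=O)OCc2ccccc2-c2ccsc2)c(F)c1`, in this assay gives 20 nM.
Compound 3, `CCCCN(CCCC)C(=O)CCCOC(=O)c1c(CC)nc(CCC)n1Cc1ccc(-c2ccccc2-c2nn[nH]n2)cc1`, in this assay gives 500 nM.

Among these three, compound 1 has the lowest number, so it is the strongest inhibitor of the set. Compound 2 is its nearest neighbour, and the gap between them lies beyond the usual scatter; compound 3 is the furthest, with a far higher number. Going by the values given here, no pair of these measured compounds differs in only one place, so the numbers show only where each stands, not what any single change does.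

Compound 4, `CCCc1nc(CC)c(C(=O)OCCCOCc2ccccc2)n1Cc1ccc(-c2ccccc2S(=O)(=O)NC(=O)OCCC(C)C)cc1F`, is not yet measured. It differs from compound 1 in one place: a group of 8 heavy atoms (7 carbon, 1 oxygen; one six-membered aromatic ring of carbon only) in place of a group of 11 heavy atoms (8 carbon, 1 nitrogen, 2 oxygen; one five-membered non-aromatic ring with 1 hetero atom, one six-membered aromatic ring of carbon only), on a saturated chain carbon, three bonds along the chain from an oxygen next to a carbonyl group. The part that changes sits on the ester chain, away from the shared core, and the two measured compounds that keep that core, compound 1 and compound 2, both give low numbers. A modest step is expected here, toward a somewhat higher number, possibly no larger than the scatter itself. For compound 4 the estimate in this assay is 6 nM, with a range from 2 nM to 25 nM, which means an expected step of a 2.0-fold higher number from compound 1 to compound 4 (0.30 log units; within the scatter).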

Compound 4, half-maximal inhibitory concentration: 2 nM
Compound 4: the middle estimate sits 3.0-fold (0.48 log units) above what was measured; the range from low to high includes it.
By their numbers in this assay, from the lowest: compounds 4 and 1 (each within the scatter of the next); then compound 2; then compound 3.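

Replacing the group of compound 1 with benzyloxy, on a saturated chain carbon, three bonds along the chain from an oxygen next to a carbonyl group, gives a 1.5-fold lower number from compound 1 to compound 4 (0.18 log units; within the scatter) in this assay, so the two compounds cannot be told apart here. Going by these compounds alone, this is the first direct reading of this position, since no earlier pair differed in only one place, and it shows that, on this background, the larger group with its five-membered non-aromatic ring and two double bonds outside aromatic rings is not required for a low number: benzyloxy, with one six-membered aromatic ring of carbon only and one hydrogen-bond acceptor, serves equally well. No measurement here explains why the two groups read alike.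

As far as these compounds go, both groups in this step carry a six-membered aromatic ring of carbon only, so it remains open whether a group without such a ring, such as an amine or a carboxylic acid, would keep the number as low at this place. From the compounds shown here alone, how a longer chain leading to benzyloxy would read is equally open.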